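Phenyl in Place of Furan-2-yl: What to Expect

This account rests on a few compounds, and the source may have more. Where it says the series, first, only, none or still open, it means among the compounds named here.

Of the compounds shown here, three have been measured in an ADME assay on HEK293 cells (Homo sapiens) for cytotoxicity, read by CCK-8 assay and cell counting, with a stated time of 2 days; on this read-out lower numbers stand for stronger inhibition and higher numbers for weaker inhibition. Compound 1 `Oc1cccc(-c2cc(-c3ccccc3)nc(-c3ccc(Cl)cc3)c2)c1` gives 11600 nM, compound 2 `Oc1cccc(-c2cc(-c3ccc(Cl)cc3)nc(-c3ccco3)c2)c1` gives 8190 nM, and compound 3 `Oc1ccc(-c2cc(-c3cccc(Cl)c3)nc(-c3ccco3)c2)cc1` gives 2880 nM. Compounds 2 and 3 contain the same atoms joined differently; the difference between the two cores is not broken down here. Compound 4 `Oc1ccc(-c2cc(-c3ccccc3)nc(-c3cccc(Cl)c3)c2)cc1` has not yet been measured.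

Compound 4 differs from compound 3 by a single change: phenyl in place of furan-2-yl on an aromatic carbon. The same kind of change separates compound 2 from compound 1: phenyl in place of furan-2-yl on an aromatic carbon. The surroundings are not identical, though: in the measured pair the changed carbon is meta to a 3-hydroxyphenyl group and meta to a 4-chlorophenyl group, whereas in compound 3 and compound 4 it is meta to a 3-chlorophenyl group and meta to a 4-hydroxyphenyl group. The measured step was a 1.4-fold higher number from compound 2 to compound 1 (0.15 log units; within the scatter).

For compound 4 a step of similar size is expected, a 1.4-fold higher number from compound 3 to compound 4 (0.14 log units; within the scatter), because the earlier pair moved by a 1.4-fold higher number from compound 2 to compound 1 (0.15 log units; within the scatter) and compound 3 starts from 2880 nM. Compound 4 is therefore estimated at 4000 nM, most likely falling between 1800 nM and 9000 nM.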

Compound 4, half-maximal inhibitory concentration: 2820 nM
Estimate against measurement, compound 4: 1.4-fold (0.15 log units) above; low and high end bracket the measured number.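

In this assay, putting phenyl in place of furan-2-yl gives a 1.0-fold lower number from compound 3 to compound 4 (0.01 log units; within the scatter), so on this core the swap stays inside the usual scatter of repeated measurements. Set beside the earlier pair, the two cores agree: the same change on two cores in this assay, a 1.4-fold higher number (0.15 log units; within the scatter) from compound 2 to compound 1 and a 1.0-fold lower number (0.01 log units; within the scatter) from compound 3 to compound 4, 1.4-fold (0.16 log units) apart, within the scatter of two such steps. Among these compounds, for these two pairs, then, the change carried from one core to the other without a visible difference, but two pairs are a small sample, and since both steps are so small, they show only that this swap made little difference on these cores, not that a larger effect would carry over in the same way.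

The compounds shown hold only phenyl or furan-2-yl at this place, so it remains open whether a different group there, such as an amine or a carboxylic acid, would also leave the number within the scatter. As far as these compounds go, it is also open whether the swap would behave the same way on a core carrying a longer chain instead of the chlorine.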